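From 3-Bromopropyl to 4-Bromobutyl: An Expected Small Step

A few compounds are considered here, and "the series" means these few. Any claim that something is new, unique, unknown or untested is made for them only; others in the source may bear on it.

Measured compounds:
- Compound 1 `COc1ccc(N(C)c2ccnc(Cl)n2)cc1F`: 241 nM
- Compound 2 `COc1ccc(N(C)c2ccnc(Cl)n2)cc1OCCCBr`: 307 nM

In a functional assay on HeLa cells (Homo sapiens) for antiproliferative activity, read by MTT assay, with a stated time of 48 h (on this read-out higher numbers stand for weaker inhibition and lower numbers for stronger inhibition), compound 2 gives 307 nM. That lies within the usual scatter of compound 1 at 241 nM, so these two results cannot be told apart.

Compound 3 `COc1ccc(N(C)c2ccnc(Cl)n2)cc1OCCCCBr` has not yet been measured. Its difference from compound 2 is this: bromomethyl in place of bromo on a saturated chain carbon, three bonds along the chain from an oxygen on an aromatic ring. In words, bromomethyl stands in place of bromo on a saturated chain carbon, three bonds along the chain from an oxygen on an aromatic ring. Put another way, 3-bromopropyl becomes 4-bromobutyl.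

Among the compounds with values here, only one measured step bears on this, and only indirectly, since it is a different change: 3-bromopropoxy in place of fluoro on an aromatic carbon. Because a 1.3-fold higher number from compound 1 to compound 2 (0.11 log units; within the scatter) stayed within the scatter, no step beyond the scatter is expected in this assay, and no direction can be named. The estimated step is a 1.0-fold lower number from compound 2 to compound 3 (0.01 log units; within the scatter). For compound 3 the expected value is 300 nM, with an estimated range of 140 nM to 640 nM.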

Compound 3, half-maximal inhibitory concentration: 307 nM
For compound 3 the middle estimate is 1.0-fold (0.01 log units) below the measured one; measured number inside the range.
By their numbers in this assay, from the lowest: compounds 1, 2 and 3 (each within the scatter of the next).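

In this assay, the move from 3-bromopropyl to 4-bromobutyl gives no change at the digits printed from compound 2 to compound 3 (within the scatter) and so adds a direct comparison at this position: the chain gains one carbon while the bromine stays at its end, and the two results cannot be told apart. Putting 4-bromobutoxy on the aromatic carbon that carries fluoro in compound 1 gives a 1.3-fold higher number from compound 1 to compound 3 (0.11 log units; within the scatter) in the same assay, so compounds 1, 2 and 3, with fluoro, 3-bromopropoxy and 4-bromobutoxy at that carbon, all lie within the scatter of one another. No accompanying measurement offers an explanation for this flat picture.

These three compounds cover only a narrow set of groups, and all of the chains shown end in bromine. From the compounds shown here alone, it remains open whether an amine or a carboxylic acid in place of that bromine, or a longer chain such as 5-bromopentyl, would still give a result within the scatter of these three.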